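Pyrazole for pyridine on a sulfonamide nitrogen

A few compounds are considered here, and "the series" means these few. Any claim that something is new, unique, unknown or untested is made for them only; others in the source may bear on it.

Measured compounds:
compound 1 `CCc1ccccc1N(CC(=O)NCc1cccc(Cl)c1)S(=O)(=O)c1ccc(C)cc1`: 1410 nM
compound 2 `Cc1ccc(S(=O)(=O)N(CC(=O)NCc2ccc(Cl)cc2)c2ccccn2)cc1`: < 1450 nM

In a functional assay on CHO-K1 cells for antagonist activity at prostaglandin E2 receptor EP1 subtype (Homo sapiens), read by FLIPR and calcium flux (on this read-out higher numbers stand for weaker inhibition and lower numbers for stronger inhibition), compound 1 gives 1410 nM. For compound 2 the same assay reports only a limit, < 1450 nM, so its true value is not pinned to a number; this is the situation described by the limit of < 1450 nM in this assay, at which 1 of the 2 values shown sits. Compound 3 `Cc1ccc(S(=O)(=O)N(CC(=O)NCc2ccc(Cl)cc2)c2ccnn2C)cc1` is not yet measured. It differs from compound 2 in one place: 1-methyl-1H-pyrazol-5-yl in place of pyridin-2-yl on a sulfonamide nitrogen, which is 1-methyl-1H-pyrazol-5-yl in place of pyridin-2-yl on a sulfonamide nitrogen. Going by the values given here, no measured pair in this set carries such a change, so no direction can be read from the data, and the expected step from compound 2 to compound 3 is taken as a step that the limit leaves unreadable from compound 2 to compound 3, nothing beyond the scatter. On that basis compound 3 is estimated at 1000 nM in this assay, within a range from 300 nM to 3000 nM.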

Compound 3, inhibition constant: 589 nM
Estimate against measurement, compound 3: 1.7-fold (0.23 log units) above; the measured number falls inside the stated range.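

No step from compound 2 to compound 3 can be read in this assay, because compound 2 is reported only as a limit: the limit of < 1450 nM in this assay, at which 1 of the 3 values shown sits.

The compounds shown leave open whether 1-methyl-1H-pyrazol-5-yl in place of pyridin-2-yl on a sulfonamide nitrogen changes inhibition, and in which direction.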